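Esterifying the Acid Chain of Compound 1

The compounds below may be only part of what the source reports. "The series", "measured", "known", "first", "only" and "open" are said of these compounds alone.

Compound 1 `COc1ncc(-c2ccc3ncnc(Nc4cnn(CCC(=O)O)c4)c3c2)cc1NS(C)(=O)=O` gives 1290 nM in a functional assay on HCT-116 cells (Homo sapiens) for antiproliferative activity, read by sulforhodamine B assay, with a stated time of 72 h; on this read-out lower numbers stand for stronger inhibition and higher numbers for weaker inhibition. Among the three measured compounds it holds the second highest number: compound 3 `COC(=O)Cn1cc(Nc2ncnc3ccc(-c4cnc(OC)c(NS(=O)(=O)c5ccc(F)cc5F)c4)cc23)cn1` gives 1260 nM, a value within the scatter of compound 1, while compound 2 `COc1ncc(-c2ccc3ncnc(Nc4ccc(OCCO)c(F)c4)c3c2)cc1NS(=O)(=O)c1ccc(F)cc1F` gives 9160 nM, a weaker result lying beyond the scatter. Going by the values given here, the only step between compounds that differ in one place, a 7.3-fold lower number from compound 2 to compound 3 (0.86 log units; beyond the scatter), concerns the group on the aromatic nitrogen and not the acid or ester. Compound 4 `COC(=O)CCn1cc(Nc2ncnc3ccc(-c4cnc(OC)c(NS(C)(=O)=O)c4)cc23)cn1` differs from compound 1 by methyl in place of hydrogen on an oxygen next to a carbonyl group. Among the compounds with values here, no measured pair isolates this change; the closest indication is that compound 3, carrying a methoxycarbonyl group, and compound 1, carrying a carboxy group, sit at numbers within the scatter of each other, although they also differ in other places. The step from compound 1 to compound 4 is therefore expected to stay within the scatter, a 1.2-fold lower number from compound 1 to compound 4 (0.07 log units; within the scatter). Compound 4 is estimated at 1100 nM, with a range from 400 nM to 3000 nM.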

Compound 4, half-maximal inhibitory concentration: 970 nM
Compound 4: the middle estimate sits 1.1-fold (0.05 log units) above what was measured; measured number inside the range.
By their numbers in this assay, from the lowest: compounds 4, 3 and 1 (each within the scatter of the next); then compound 2.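

In this assay, methyl in place of hydrogen on an oxygen next to a carbonyl group, which turns carboxy into methoxycarbonyl, gives a 1.3-fold lower number from compound 1 to compound 4 (0.12 log units; within the scatter). This is the first pair shown that differs in this one place alone, and it shows directly that the two groups cannot be told apart in this read-out when they end this chain. Nothing available accounts for this outcome.

The compounds shown leave open whether an amine or a primary amide in place of the carboxy group, or a longer chain, would give a step beyond the scatter. They also leave open whether carboxymethyl to (methoxycarbonyl)methyl, the same difference on the shorter chain of compound 3, would remain as small.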